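The compounds below may be only part of what the source reports. "The series", "measured", "known", "first", "only" and "open" are said of these compounds alone.

Values measured so far in an ADME assay on CEM-SS cells (Homo sapiens) for cytotoxicity, read by XTT assay, with a stated time of 6 days; on this read-out lower numbers stand for higher toxicity in this test and higher numbers for lower toxicity in this test:
- compound 1 `CCCC(=O)OCSc1ccc(OC(F)(F)F)cc1C(=O)NC(C)(C)C(N)=O`: < 56.1 uM
- compound 2 `CCCC(=O)OCSc1ccccc1C(=O)NCC(N)=O`: > 100 uM
- compound 3 `CCCC(=O)OCSc1ccccc1C(=O)NC1(C(N)=O)CCCC1`: > 100 uM

None of these three results is an exact number. Compound 1 gives < 56.1 uM, which is a limit of the assay. Compound 2 gives > 100 uM, also a limit. Compound 3 gives > 100 uM, again a limit, so its position is known only as a bound.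

The next compound is compound 4 `CCCC(=O)OCSc1ccccc1C(=O)NCCCCCC(N)=O`. It differs from compound 3 as follows: 5-carbamoylpentyl in place of 1-carbamoylcyclopentyl on an amide-type nitrogen. The ring of the 1-carbamoylcyclopentyl group is gone, and the open 5-carbamoylpentyl chain takes its place on the same amide-type nitrogen.

For the measured compounds named here, only one measured step changes a group at this place: a step that the two limits leave unreadable from compound 2 to compound 3. It offers no size to carry over to the new change. What remains is the shared position of the two compounds with this core and no further substituent, (the limit of > 100 uM in this assay, at which 2 of the 3 values shown sit).

No change beyond the usual scatter is therefore expected, and the estimated step is a number no higher from compound 3 to compound 4 (the limit leaves the size open). A report as a limit is the likeliest outcome for compound 4. If a number is reported, the expected value for compound 4 is 100 uM, with an estimated range from 45 uM to 220 uM.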

Compound 4, half-maximal toxic concentration: 16.3 uM
Compound 4: the middle estimate sits 6.1-fold (0.79 log units) above what was measured; the measured number lies below the stated range.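

In this assay, the open 5-carbamoylpentyl chain on the amide-type nitrogen gives an at least 6.1-fold lower number from compound 3 to compound 4 (0.78 log units; beyond the scatter). The two groups match in their counts of heavy atoms, hydrogen-bond donors and hydrogen-bond acceptors, and they differ in that 1-carbamoylcyclopentyl holds a five-membered ring while 5-carbamoylpentyl has no ring, so the same atoms arranged differently are enough to bring out higher toxicity in this test. Placing 4-carbamoylbutyl in place of carbamoyl on the saturated chain carbon bound to the amide-type nitrogen likewise gives an at least 6.1-fold lower number from compound 2 to compound 4 (0.78 log units; beyond the scatter), whereas the step between the two earlier compounds with this core cannot be read, as both of their results are limits.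

Nothing in the data shown gives a reason for the lower number with this chain. The compounds shown leave open whether the toxicity follows the length of the chain, the loss of the ring or the carbamoyl at the chain's end, a question that a shorter 3-carbamoylpropyl chain or the same pentyl chain ending in a carboxylic acid would help to separate.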